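The source may hold more compounds than are shown below. What is called first, only, known or untested is meant among the compounds shown, and "the series" means these compounds.

Measured so far:
- compound 1, `CCOC(=O)c1sc(-c2cccc(NC(=O)c3cccc(F)c3)c2)nc1Nc1ccc(N2CCN(C)CC2)cc1`, 21200 nM in a functional assay on Raji cells (Homo sapiens) for antiproliferative activity, read by CCK-8 assay, with a stated time of 72 h; on this read-out lower numbers stand for stronger inhibition and higher numbers for weaker inhibition
- compound 2, `CCOC(=O)c1sc(-c2cccc(NC(=O)c3ccc(Cl)cc3)c2)nc1Nc1ccc(N2CCN(C)CC2)cc1`, "not determined" (no result reported) in this assay
- compound 3, `CCOC(=O)c1sc(-c2cccc(NC(=O)c3ccc(C(F)(F)F)cn3)c2)nc1Nc1ccc(N2CCN(C)CC2)cc1`, "not determined" (no result reported) in this assay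

Only compound 1 carries a number in this assay, and that number is high, so compound 1 inhibits cell growth weakly. Compound 3 stands without any number; its result in this assay was not reported, and compound 2 is in the same position, so nothing ranks compound 3 against the others.

The step to compound 4, `CN1CCN(c2ccc(Nc3nc(-c4cccc(NC(=O)c5ccc(C(F)(F)F)cn5)c4)sc3C(N)=O)cc2)CC1`, changes one group: amino in place of ethoxy on a carbonyl carbon. Going by the values given here, no measured pair shows what such a change does in this assay here. With only the weak value of compound 1 as a reference for the whole shared core, the expectation is a step of moderate size toward stronger inhibition, though a step within the usual scatter cannot be ruled out.

Compound 4 is therefore estimated to give about 8000 nM in this assay, expected to fall between 1500 nM and 40000 nM.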

Compound 4, half-maximal inhibitory concentration: 24500 nM
Compound 4: middle estimate off by 3.1-fold (0.49 log units), on the low side; the range from low to high includes it.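

In this assay, going by these compounds alone, compound 3 has no single number, so the change from ethoxycarbonyl to carbamoyl that leads to compound 4 gives no step that can be read. As far as these compounds go, what this change does to cell growth inhibition stays open. No measured data here explain the value of compound 4.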